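This account rests on a few compounds, and the source may have more. Where it says the series, first, only, none or still open, it means among the compounds named here.

Measured in a functional assay on K562 cells (Homo sapiens) for cytotoxicity, read by sulforhodamine B assay; a lower number here means that less compound is tolerated, a higher number that more compound is tolerated:

- Compound 1 `CC1=CC[C@@H]([C@@](C)(O)CCCC(C)(C)NC(=S)N/N=C\c2ccc(O)cc2)CC1` gives > 100000 nM, a limit of the assay.
- Compound 2 `CC1=CC[C@@H]([C@@](C)(O)CCCC(C)(C)NC(=S)N/N=C\c2ccc(N(C)C)cc2)CC1` gives > 100000 nM, a limit of the assay.
- Compound 3 `CC1=CC[C@@H]([C@@](C)(O)CCCC(C)(C)NC(=S)N/N=C\c2cccc([N+](=O)[O-])c2)CC1` gives 12600 nM, a measured number.

Going by the values given here, compound 3 holds the only true number of the three, the other two values being limits (the limit of > 100000 nM in this assay, at which 2 of the 3 values shown sit). The next compound, compound 4 `CC1=CC[C@@H]([C@@](C)(O)CCCC(C)(C)NC(=S)N/N=C\c2ccc([N+](=O)[O-])cc2)CC1`, has the same atoms joined differently, with 4-nitrophenyl in place of 3-nitrophenyl on a carbon with a double bond to nitrogen.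

Among the compounds with values here, two measured steps bear on this change: an at least 7.9-fold lower number from compound 1 to compound 3 (0.89 log units; beyond the scatter) and an at least 7.9-fold lower number from compound 2 to compound 3 (0.89 log units; beyond the scatter). Both lie beyond the scatter and both bring in the 3-nitrophenyl, but each removes a different substituted phenyl, so neither shows what moving the nitro group does. The remaining step, a step that the two limits leave unreadable from compound 1 to compound 2, adds nothing on size. Compound 4 keeps the nitro group carried by compound 3 at 12600 nM, so a value near that number is expected, with no step beyond the scatter in either direction. The expected step is a 1.2-fold higher number from compound 3 to compound 4 (0.08 log units; within the scatter), and it is uncertain. For compound 4 the estimated value in this assay is 15000 nM, with an expected range from 5000 nM to 50000 nM.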

Compound 4, concentration lethal to 50% of the cells: 45500 nM
Beside the measured number, compound 4's estimate is 3.0-fold (0.48 log units) below it; the measured number falls inside the stated range.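

In this assay, going by these compounds alone, where the nitro group sits on the phenyl ring matters in its own right, with a 3.6-fold higher number from compound 3 to compound 4 (0.56 log units; beyond the scatter); the earlier steps each exchanged one substituted phenyl for another and could not separate this placement from the identity of the group. The 4-nitrophenyl still stands apart from the other two groups at the same place, with an at least 2.1-fold lower number from compound 2 to compound 4 (0.34 log units; beyond the scatter) and an at least 2.1-fold lower number from compound 1 to compound 4 (0.34 log units; beyond the scatter), so nitro in place of dimethylamino or hydroxy on an aromatic carbon goes with a lower number even without the 3-nitrophenyl. These two steps give only bounds on size, as compound 1 and compound 2 stand at a limit: the limit of > 100000 nM in this assay, at which 2 of the 4 values shown sit.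

The compounds shown leave open whether the difference between the 3-nitrophenyl and the 4-nitrophenyl is particular to nitro, a question that a 3-hydroxyphenyl or a 3-(dimethylamino)phenyl would help to settle. They also leave open how a nitrile or a trifluoromethyl on the same ring would compare with nitro in either printed arrangement.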